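A few compounds are considered here, and "the series" means these few. Any claim that something is new, unique, unknown or untested is made for them only; others in the source may bear on it.

In an ADME assay on BJ cells (Homo sapiens) for cytotoxicity, with a stated time of 72 h (a higher number here means that more compound is needed for the effect, a lower number that less compound is needed), compound 1 `Cc1cc(NC(=O)c2cc([N+](=O)[O-])ccc2Cl)cc(-c2nc3ccccc3o2)c1O` gives > 25000 nM, which is a limit of the assay and not a number. Compound 2 `O=C(Nc1ccc(O)c(-c2nc3ccccc3s2)c1)c1cc([N+](=O)[O-])ccc1Cl` gives > 25000 nM in this assay, again a limit and not a number. Compound 2 therefore has no exact position in the series, and all that can be read from the data is the limit of > 25000 nM in this assay, at which 2 of the 2 values shown sit. Going by the values given here, no step between measured compounds is available to size a change directly.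

Compound 3 `Cc1cc(NC(=O)c2cc([N+](=O)[O-])ccc2Cl)cc(-c2nc3ccccc3s2)c1O` differs from compound 2 by a single change, methyl in place of hydrogen on an aromatic carbon, ortho to a hydroxy group: methyl in place of hydrogen on an aromatic carbon. The expectation rests partly on compound 1, which also carries a methyl group and gives > 25000 nM, a limit of the assay. The expected step of a number no higher from compound 2 to compound 3 (the limit leaves the size open) in this assay is none beyond the scatter, with no direction favoured. For compound 3 the estimated value is 25000 nM, with an expected range of 10000 nM to 50000 nM, and a report as a limit is the most likely outcome.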

Compound 3, half-maximal effective concentration: > 25000 nM
Compound 3: a limit, no number; the forecaster's own chance of this, stated with the estimate: 80%; the middle value sits exactly at the limit.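

In this assay compound 3 gives > 25000 nM, a limit and not a number. No step can be read from compound 2 to compound 3 or from compound 1 to compound 3, and the series offers a single reading: the limit of > 25000 nM in this assay, at which 3 of the 3 values shown sit. The compounds shown leave open which change, if any, would give an exact value in this assay.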